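Adding hydroxy to the benzyl of compound 3

The compounds below may be only part of what the source reports. "The series", "measured", "known", "first", "only" and "open" are said of these compounds alone.

In an ADME assay on HEK-293T cells (Homo sapiens) for cytotoxicity, read by MTT assay, with a stated time of 3 days (a higher number here means that more compound is tolerated, a lower number that less compound is tolerated), compound 1 (`O=C(COC(=O)c1ccc([N+](=O)[O-])o1)NCC1CCCO1`) reads > 100000 nM as a limit of the assay and not a number. Compound 3 (`O=C(OCC(=O)N(Cc1ccccc1)CC1CCCO1)c1ccc([N+](=O)[O-])o1`) reads > 100000 nM as a limit of the assay as well. Going by the values given here, compound 2 (`CC(C)(C)N(Cc1ccccc1C(F)(F)F)C(=O)COC(=O)c1ccc([N+](=O)[O-])o1`) is the one member with a number, at 65000 nM in this read-out. Compound 3 thus stands at the limit of > 100000 nM in this assay, at which 2 of the 3 values shown sit, and has no number of its own.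

Compound 4 (`O=C(OCC(=O)N(Cc1ccc(O)cc1)CC1CCCO1)c1ccc([N+](=O)[O-])o1`) differs from compound 3 by hydroxy in place of hydrogen on an aromatic carbon (benzyl to 4-hydroxybenzyl). Among the compounds with values here, the one measured step at this nitrogen substituent is a step that the two limits leave unreadable from compound 1 to compound 3 and it offers no size to carry over. Within the data shown here, no measured step covers hydroxy in place of hydrogen on an aromatic carbon. The expectation from the limit of compound 3 (> 100000 nM) is no step beyond the scatter in this assay and most likely another limit. The estimated value for compound 4 is 100000 nM (expected range 50000 nM to 200000 nM).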

Compound 4, half-maximal cytotoxic concentration: > 100000 nM
Compound 4 was reported as a limit (the forecaster's own chance of this, stated with the estimate: 75%); the middle value lies on the limit itself.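

Going by these compounds alone, compound 1, compound 3 and compound 4 all read only as limits of the assay, and no step among them can be read. The compounds shown leave open how far any of the three lies beyond that limit in this assay, and whether hydroxy on the benzyl shifts the read-out at all.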